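From 4-hydroxyphenyl to 4-fluoro-2-nitrophenyl on the sulfonyl sulfur

This account rests on a few compounds, and the source may have more. Where it says the series, first, only, none or still open, it means among the compounds named here.

In a functional assay on DU-145 cells (Homo sapiens) for inhibition, read by trypan blue exclusion, with a stated time of 72 h (a lower number here means a stronger inhibitor, a higher number a weaker inhibitor), compound 1 (`Cn1c(=O)c(S(=O)(=O)Cc2ccc(F)cc2F)cc2cnc(Nc3ccc4[nH]ccc4c3)nc21`) gives 1000 nM with 2,4-difluorobenzyl on the sulfonyl sulfur. Compound 2 (`Cn1c(=O)c(S(=O)(=O)c2ccc(O)cc2)cc2cnc(Nc3ccc4[nH]ccc4c3)nc21`) gives 250 nM with 4-hydroxyphenyl at that place and so holds the lower of the two numbers. Among the compounds with values here, the only measured step is a 4.0-fold lower number from compound 1 to compound 2 (0.60 log units; beyond the scatter) and it is modest but beyond the scatter.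

Compound 3 (`Cn1c(=O)c(S(=O)(=O)c2ccc(F)cc2[N+](=O)[O-])cc2cnc(Nc3ccc4[nH]ccc4c3)nc21`) keeps the shared core and differs from compound 2 at the same sulfur (4-fluoro-2-nitrophenyl in place of 4-hydroxyphenyl on a sulfonyl sulfur) with 4-fluoro-2-nitrophenyl in place of 4-hydroxyphenyl. Within the data shown here, no measured compound carries this new group, and the one measured step shows only that a change at this place can move the number by a modest amount. It gives no direction for the new group. Among the measured compounds shown here, with compound 2 at 250 nM as the lower of only two numbers, a small rise seems more likely than a further fall. In this assay the expected step is a 2.2-fold higher number from compound 2 to compound 3 (0.34 log units; beyond the scatter) as an estimate, smaller than the measured one. Compound 3 is estimated at 550 nM with 150 nM to 2000 nM as the expected range.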

Compound 3, half-maximal inhibitory concentration: 1500 nM
Compound 3: the middle estimate sits 2.7-fold (0.44 log units) below what was measured, and the stated range covers the measured number.
By their numbers in this assay, from the lowest: compound 2; then compounds 1 and 3 (each within the scatter of the next).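

In this assay, replacing 4-hydroxyphenyl with 4-fluoro-2-nitrophenyl on the sulfonyl sulfur gives a 6.0-fold higher number from compound 2 to compound 3 (0.78 log units; beyond the scatter) and so shows that the number at this position depends on what the six-membered aromatic ring carries, not only on the ring being present. The second new step, a 1.5-fold higher number from compound 1 to compound 3 (0.18 log units; within the scatter), puts 4-fluoro-2-nitrophenyl and 2,4-difluorobenzyl level with each other despite their different groups, which leaves compound 2 as the strongest of the three, with both of its steps beyond the scatter. No measurement shown here accounts for the change in number at this position.

The change from compound 2 to compound 3 removes a hydroxyl group and adds both a nitro group and a fluorine, so the compounds shown do not tell which of these alterations carries the step. Unsubstituted phenyl, 4-methoxyphenyl or 4-aminophenyl on the same sulfur would help separate them, and it remains open whether any group at this place gives a lower number than 4-hydroxyphenyl.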